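This account rests on a few compounds, and the source may have more. Where it says the series, first, only, none or still open, it means among the compounds named here.

Within the data shown here, in an assay on HeLa cells for inhibition of sphingosine-1-phosphate transporter SPNS2 (Mus musculus), read by LC-MS, tested at 2 uM (a higher number here means more inhibition at the concentration tested (going by the name of the read-out), a lower number less inhibition), compound 2 `CCCCCCCCCCc1ccc(-c2noc(CCCN3CCCC3)n2)cc1` gives 3%, the lowest of the two numbers so far. Among the measured compounds shown here, compound 1 `CCCCCCCCCCc1ccc(-c2noc(CC[C@@H](N)C(=O)O)n2)cc1` gives 5%, and the one measured step, a number 2 percentage points lower from compound 1 to compound 2 (within the scatter), lies within the scatter. Compound 3 `CCCCCCCCCCc1ccc(-c2noc(CC(O)CN3CCCCC3)n2)cc1` differs from compound 2 by 1-hydroxy-2-(piperidin-1-yl)ethyl in place of 2-(pyrrolidin-1-yl)ethyl on a saturated chain carbon bound to an aromatic carbon. For the measured compounds named here, that single measured step sits at a different place on the shared core and is the only guide; both measured numbers lie near the bottom of the scale. No step beyond the scatter is therefore expected, and the expected step is a number 2 percentage points higher from compound 2 to compound 3 (within the scatter). For compound 3 the estimate is 5%, in the range -5% to 15%.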

Compound 3, a percentage reported as inhibition, at one concentration (the size of the read-out at that concentration, not a potency): 2%
Estimate against measurement, compound 3: 3 percentage points above; measured number inside the range.
By their numbers in this assay, from the lowest: compounds 3, 2 and 1 (each within the scatter of the next).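

In this assay, a number 1 percentage points lower from compound 2 to compound 3 (within the scatter) comes with the change to 1-hydroxy-2-(piperidin-1-yl)ethyl on a saturated chain carbon bound to an aromatic carbon, so this combined change shows no readable effect here. The same group in place of 2-amino-2-carboxyethyl gives a number 3 percentage points lower from compound 1 to compound 3 (within the scatter) and so also shows none. No measurement available bears on why these numbers stay together.

The hydroxy group and the six-membered ring enter together, so neither can be read alone. Going by these compounds, whether a carboxylic acid without the amine, or a longer chain, reads differently at this place remains open.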